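The compounds below may be only part of what the source reports. "The series", "measured", "known", "first", "only" and "open" are said of these compounds alone.

Compounds measured so far:

Compound 1 `CNC(=O)c1cnc(N2CCN(C3CCN(Cc4ccc[nH]4)CC3)[C@@H](C)C2)c(Cl)c1`: 8060 nM
Compound 2 `CNC(=O)c1cnc(N2CCN(C3CCN(Cc4ccccn4)CC3)[C@@H](C)C2)c(Cl)c1`: 7990 nM
Compound 3 `CNC(=O)c1cnc(N2CCN(C3CCN(Cc4ccc(C)cc4)CC3)[C@@H](C)C2)c(Cl)c1`: 87 nM

In a functional assay for antagonist activity at C-X-C chemokine receptor type 3 (Homo sapiens) (a lower number here means a stronger inhibitor, a higher number a weaker inhibitor), compound 3 stands lowest of the three; its nearest neighbour is compound 2 and the gap is a 92-fold lower number from compound 2 to compound 3 (1.96 log units; beyond the scatter), while the gap from compound 1 is a 93-fold lower number from compound 1 to compound 3 (1.97 log units; beyond the scatter). Compounds 1 and 2 lie within the scatter of each other, a 1.0-fold lower number from compound 1 to compound 2 (0.00 log units; within the scatter).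

Compound 4 `CNC(=O)c1cnc(N2CCN(C3CCN(Cc4ccc(F)cc4Cl)CC3)[C@@H](C)C2)c(Cl)c1` differs from compound 3 in one place: 2-chloro-4-fluorophenyl in place of 4-methylphenyl on a saturated chain carbon bound to an amine nitrogen in a ring. Among the compounds with values here, the steps that bear on it are those into compound 3, both of which exchange a heteroaryl group for 4-methylphenyl and both of which are large. Compound 4 keeps a six-membered aromatic ring of carbon only, so the part of the change that drove those steps is retained; what is not measured anywhere here is the exchange of methyl for chlorine and fluorine on that ring. Within the data shown here, with no step on that exchange, the expected step in this assay is a 1.1-fold higher number from compound 3 to compound 4 (0.06 log units; within the scatter), none beyond the scatter. Compound 4 is therefore estimated at 100 nM, with a range from 30 nM to 400 nM.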

Compound 4, half-maximal inhibitory concentration: 58 nM
Compound 4: the middle estimate sits 1.7-fold (0.24 log units) above what was measured, within the range that was stated.
By their numbers in this assay, from the lowest: compounds 4 and 3 (each within the scatter of the next); then compounds 2 and 1 (each within the scatter of the next).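

In this assay, exchanging 4-methylphenyl for 2-chloro-4-fluorophenyl on a saturated chain carbon bound to an amine nitrogen in a ring gives a 1.5-fold lower number from compound 3 to compound 4 (0.18 log units; within the scatter), so this position accepts a quite different set of ring substituents with no change that can be told from the scatter. The steps from the two heteroaryl compounds stay large, at a 140-fold lower number from compound 2 to compound 4 (2.14 log units; beyond the scatter) and a 140-fold lower number from compound 1 to compound 4 (2.14 log units; beyond the scatter), so among the four compounds shown the wide gap no longer rests on 4-methylphenyl alone: both compounds with a six-membered aromatic ring of carbon only lie far below both compounds with a heteroaryl ring, and none of the four goes against this. Nothing available here accounts for either the large steps or the small one.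

The compounds shown leave open whether chlorine or fluorine alone would serve as the pair does, and how an unsubstituted phenyl or a methoxy group on the ring would read in this assay. They also leave open whether a pyridin-2-yl ring carrying chlorine and fluorine would close the gap to the carbon-only rings, and what a longer chain to the amine nitrogen would do.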